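Adding a Methyl to the Core of Compound 3

The source may report more compounds than this note shows. Statements on the series, on what has been measured and on what is new or still open speak of the compounds shown alone.

Measured so far:
compound 1 `C#CCCCOc1ccc2c(C)cc(=O)oc2c1` gives 18.2 nM
compound 2 `C#CCCCCOc1ccc2cc(NC(C)=O)c(=O)oc2c1` gives 41.7 nM
compound 3 `C#CCCCCOc1ccc2ccc(=O)oc2c1` gives 2.62 nM

The measurement is an assay on cells for inhibition of Amine oxidase [flavin-containing] B (Homo sapiens), read by Amplex Red, with stated times of 30 min and 45 min; a higher number here means a weaker inhibitor, a lower number a stronger inhibitor. Of the three numbers, compound 3 has the lowest, so it is the strongest inhibitor here; compound 1 sits higher by a margin beyond the scatter, and compound 2 higher still. Within the data shown here, the only step between two compounds that differ in a single place is a 16-fold lower number from compound 2 to compound 3 (1.20 log units; beyond the scatter), where removing the acetamido from the shared core made the inhibitor much stronger.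

Compound 4 `C#CCCCCOc1ccc2c(C)cc(=O)oc2c1` is the next compound, not yet measured. It differs from compound 3 in one place: methyl in place of hydrogen on an aromatic carbon. Among the measured compounds shown here, no measured step bears directly on this change. Compound 1 carries the same methyl but also a shorter chain, so its higher number against compound 3 cannot be assigned to the methyl alone. The expectation is therefore a modest shift, a 2.3-fold higher number from compound 3 to compound 4 (0.36 log units; beyond the scatter), probably toward a higher number. Compound 4 is estimated at 6 nM, with a range of 2 nM to 20 nM.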

Compound 4, half-maximal inhibitory concentration: 0.77 nM
For compound 4 the middle estimate is 7.8-fold (0.89 log units) above the measured one; measured number below the stated range.
By their numbers in this assay, from the lowest: compound 4; then compound 3; then compound 1; then compound 2.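

In this assay, methyl in place of hydrogen on this aromatic carbon, opposite the ring oxygen, gives a 3.4-fold lower number from compound 3 to compound 4 (0.53 log units; beyond the scatter) and so makes the inhibitor stronger, showing that this position accepts a methyl with a gain, not a loss. With the methyl now held constant, propargyl in place of ethynyl on a saturated chain carbon gives a 24-fold lower number from compound 1 to compound 4 (1.37 log units; beyond the scatter) and separates the chain from the methyl, so the higher number of compound 1 belongs to its chain end. Nothing measured here explains why either change lowers the number.

Still open, going by these compounds, is whether a larger group at this carbon, such as an ethyl or a methoxy, would keep the gain. It is also unknown whether a longer chain would lower the number further, or whether the methyl would give a similar step on the chain of compound 1.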